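Working notes on compound 4 and its measured neighbours

The compounds below may be only part of what the source reports. "The series", "measured", "known", "first", "only" and "open" are said of these compounds alone.

Measured so far in a functional assay on MCF7 cells (Homo sapiens) for cytotoxicity, read by MTT assay, with a stated time of 72 h; on this read-out higher numbers stand for weaker inhibition and lower numbers for stronger inhibition:
compound 1 `COc1cc2ncnc(Nc3ccc(F)c(Cl)c3)c2cc1NC(=O)/C=C/c1ccc(C#N)cc1` — "not active" (no number reported)
compound 2 `COc1cc2ncnc(Nc3ccc(F)c(Cl)c3)c2cc1NC(=O)/C=C/c1cc(OC)c(OC)c(OC)c1` — "not active" (no number reported)
compound 3 `COc1cc2ncnc(Nc3ccc(F)c(Cl)c3)c2cc1NC(=O)/C=C/c1ccccc1[N+](=O)[O-]` — 36500 nM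

Going by the values given here, compound 3 holds the only number in this assay; compound 1 and compound 2 carry no number, only a report of no activity, so no step between measured compounds can be given. Compound 4 `COc1cc2ncnc(Nc3ccc(F)c(Cl)c3)c2cc1NC(=O)/C=C/c1ccc(F)cc1Cl` is not yet measured. It differs from compound 3 by 2-chloro-4-fluorophenyl in place of 2-nitrophenyl on a double-bonded chain carbon bound to a double-bonded chain carbon. Among the compounds with values here, with no measured step to lean on, the expectation for compound 4 is no change beyond the scatter, with weak cytotoxicity kept. Compound 4 is expected near 30000 nM, with a range of 10000 nM to 100000 nM. The step from a 1.2-fold lower number from compound 3 to compound 4 (0.09 log units; within the scatter) is the estimated movement, judged to lie within scatter.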

Compound 4, half-maximal inhibitory concentration: "not active" (no number reported)
No number was reported for compound 4, so the estimate cannot be set against anything.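

Going by these compounds alone, compound 4 carries only a report of no activity, so no step from compound 3, at 36500 nM, can be read. The compounds shown leave open how the aryl groups on the ethenyl chain rank against one another. No evidence bears on this result.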